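This account rests on a few compounds, and the source may have more. Where it says the series, first, only, none or still open, it means among the compounds named here.

The series shares one core: compound 1 `COc1cc2c(Oc3ccc(NC(=O)c4cc(-c5ccccc5)ccn4)cc3F)ccnc2cc1OCCCN1CCN(C)CC1`, compound 2 `COc1cc2c(Oc3ccc(NC(=O)c4cc(-c5ccc(C(F)(F)F)cc5)ccn4)cc3F)ccnc2cc1OCCCN1CCN(C)CC1` and compound 3 `COc1cc2c(Oc3ccc(NC(=O)c4cc(-c5ccccc5)ccn4)cc3F)ccnc2cc1OCCCN1CCCC1` differ in the amine on the chain or on the phenyl. In a functional assay on U-87MG ATCC cells (Homo sapiens) for cytotoxicity, read by MTT assay, with a stated time of 72 h (a higher number here means a weaker inhibitor, a lower number a stronger inhibitor), compound 1 gives 1010 nM. Compound 2, which carries a trifluoromethyl group on that phenyl, gives "not determined" (no result reported) in this assay, so no number is reported for it. Compound 3 gives 1010 nM in this assay, and the step of no change at the digits printed from compound 1 to compound 3 (within the scatter) shows that exchanging the amine on the chain left the value where it was. So compound 3 stands level with compound 1; nothing measured separates the two.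

Compound 4 `COc1cc2c(Oc3ccc(NC(=O)c4cc(-c5ccccc5F)ccn4)cc3F)ccnc2cc1OCCCN1CCCC1` differs from compound 3 by fluoro in place of hydrogen on an aromatic carbon. Among the measured compounds shown here, no measured step touches that phenyl with a number, since compound 2 lacks a result; the only step in hand concerns the amine on the chain and was flat. A step of about a 1.0-fold lower number from compound 3 to compound 4 (0.00 log units; within the scatter) is therefore expected, none beyond the scatter. Compound 4 is estimated at 1000 nM in this assay, within 400 nM to 2500 nM.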

Compound 4, half-maximal inhibitory concentration: 610 nM
Compound 4: the middle estimate sits 1.6-fold (0.21 log units) above what was measured; the measured number falls inside the stated range.
By their numbers in this assay, from the lowest: compounds 4, 1 and 3 (each within the scatter of the next).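

Among the compounds shown here, this is the first number for a change on the phenyl itself, since compound 2 offers none. In this assay, fluoro in place of hydrogen on an aromatic carbon, ortho to a large group, gives a 1.7-fold lower number from compound 3 to compound 4 (0.22 log units; within the scatter), so this change is not separated from the unsubstituted phenyl. Nothing measured alongside these compounds accounts for the step or bears on it.

On these data alone, whether a larger or differently charged group at this carbon, such as methoxy or a carboxylic acid, would move the number beyond the scatter remains open. Also open, as far as these compounds go, is whether the 2-fluorophenyl group would read the same with 4-methylpiperazin-1-yl on the chain in place of pyrrolidin-1-yl.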